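Thiophen-3-yl replacing 2-(methylsulfonyl)phenyl on the shared core

The source may hold more compounds than are shown below. What is called first, only, known or untested is meant among the compounds shown, and "the series" means these compounds.

In an ADME assay on microsomes from liver (Homo sapiens) for metabolic stability, read by LC-MS, tested at 1 mM (a higher number here means that the compound lasts longer, a lower number that the compound disappears faster), compound 2 `CS(=O)(=O)c1ccccc1-c1c[nH]c2c(=O)n(Cc3cc(F)ccc3C#N)c(N3CCC[C@@H](N)C3)nc12` gives > 3.33 h, which is a limit of the assay and not a number. Compound 1 `N#Cc1ccc(F)cc1Cn1c(N2CCC[C@@H](N)C2)nc2c(-c3ccc(S(N)(=O)=O)cc3)c[nH]c2c1=O` also gives > 3.33 h, again a limit. Compound 3 `CS(=O)(=O)c1ccc(-c2c[nH]c3c(=O)n(Cc4cc(F)ccc4C#N)c(N4CCC[C@@H](N)C4)nc23)c(F)c1` likewise gives > 3.33 h, a limit. The steps a step that the two limits leave unreadable from compound 1 to compound 2, a step that the two limits leave unreadable from compound 1 to compound 3 and a step that the two limits leave unreadable from compound 2 to compound 3 cannot be sized because of the limit of > 3.33 h in this assay, at which 3 of the 3 values shown sit. Compound 4 `N#Cc1ccc(F)cc1Cn1c(N2CCC[C@@H](N)C2)nc2c(-c3ccsc3)c[nH]c2c1=O` differs from compound 2 by thiophen-3-yl in place of 2-(methylsulfonyl)phenyl on an aromatic carbon. Going by the values given here, none of the measured steps bears readably on this change, and the limit values give no size of step to expect in this assay beyond the scatter, in either direction. Compound 4 is estimated at 3 h, with a range from 1 h to 5 h. The step of an at least 1.1-fold lower number from compound 2 to compound 4 (0.04 log units; that floor lies within the scatter) is therefore expected to stay within the scatter.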

Compound 4, half-life: 2.67 h
Estimate against measurement, compound 4: 1.1-fold (0.05 log units) above; measured number inside the range.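

In this assay, going by these compounds alone, compound 4 is the first compound with a substituent at this aromatic carbon to give a number and not a limit, so thiophen-3-yl provides a reference value for the series. Its steps can be read only as floors (  an at least 1.2-fold lower number from compound 2 to compound 4 (0.09 log units; that floor lies within the scatter); an at least 1.2-fold lower number from compound 3 to compound 4 (0.09 log units; that floor lies within the scatter); an at least 1.2-fold lower number from compound 1 to compound 4 (0.09 log units; that floor lies within the scatter)). The steps among compound 1, compound 2 and compound 3 remain unreadable: the limit of > 3.33 h in this assay, at which 3 of the 4 values shown sit.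

Going by these compounds, the true size of the change from each larger aryl group to thiophen-3-yl stays open. Also open, on these data alone, is what an amine or a carboxylic acid at this aromatic carbon would give.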